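Trimethoxyphenyl triazole ethers: methyl to 4-fluorophenyl step

The source may report more compounds than this note shows. Statements on the series, on what has been measured and on what is new or still open speak of the compounds shown alone.

Measured compounds:
compound 1 `COc1cc(COCc2cn(Cc3cc(C)cnc3Cl)nn2)cc(OC)c1OC` 34800 nM
compound 2 `COc1cc(-c2cc(COCc3cn(Cc4cc(C)cnc4Cl)nn3)on2)cc(OC)c1OC` 39800 nM
compound 3 `COc1cc(COCc2cn(Cc3cc(-c4ccc(F)cc4)cnc3Cl)nn2)cc(OC)c1OC` 38800 nM

In a functional assay on DU-145 cells (Homo sapiens) for cytotoxicity, read by MTT assay, with a stated time of 48 h (a higher number here means a weaker inhibitor, a lower number a stronger inhibitor), compound 1 gives 34800 nM and compound 3 gives 38800 nM. The two differ by one change, (4-fluorophenyl in place of methyl on an aromatic carbon), and the step is a 1.1-fold higher number from compound 1 to compound 3 (0.05 log units; within the scatter). Compound 2 carries a different core; the difference between the core of compound 1 and that of compound 2 is not broken down here. Compound 2 gives 39800 nM in this assay, and its value and that of compound 3 lie within the scatter of one another.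

Compound 4 `COc1cc(-c2cc(COCc3cn(Cc4cc(-c5ccc(F)cc5)cnc4Cl)nn3)on2)cc(OC)c1OC` is not yet measured. It stands to compound 2 as compound 3 stands to compound 1: the change is 4-fluorophenyl in place of methyl on an aromatic carbon, at a place described in the same words. The expected step is a 1.1-fold higher number from compound 2 to compound 4 (0.02 log units; within the scatter), resting on the step of a 1.1-fold higher number from compound 1 to compound 3 (0.05 log units; within the scatter), which lay within the scatter. In this assay compound 4 is therefore estimated at 42000 nM, within 25000 nM to 75000 nM.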

Compound 4, half-maximal inhibitory concentration: 31900 nM
Beside the measured number, compound 4's estimate is 1.3-fold (0.12 log units) above it, and the stated range covers the measured number.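

In this assay the exchange of methyl for 4-fluorophenyl gives a 1.2-fold lower number from compound 2 to compound 4 (0.10 log units; within the scatter) and so no readable shift on the core of compound 2. Set beside the earlier step, the result on the two cores agrees: the same change on two cores in this assay, a 1.1-fold higher number (0.05 log units; within the scatter) from compound 1 to compound 3 and a 1.2-fold lower number (0.10 log units; within the scatter) from compound 2 to compound 4, 1.4-fold (0.14 log units) apart, within the scatter of two such steps. Among these compounds, this shows that the change stays too small to read on both cores, but it gives no direction for the step, and with both steps within the scatter it cannot show whether a change with a real effect would carry over in the same way.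

The compounds shown leave open whether an amine, a carboxylic acid or a longer chain on this aromatic carbon would move the number beyond the scatter on either core.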